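From phenethyl to 4-chlorobenzyl on the thioether

The source may hold more compounds than are shown below. What is called first, only, known or untested is meant among the compounds shown, and "the series" means these compounds.

The study measures growth inhibition in a functional assay on PC-9 cells (Homo sapiens) for inhibition, read by MTT assay, with a stated time of 72 h; a higher number here means a weaker inhibitor, a lower number a stronger inhibitor. Compound 1, with structure `Cc1cc(Nc2cc(-c3ccccc3)[nH]n2)n2nc(SCCc3ccccc3)nc2n1`, gives 4930 nM in this assay, the lowest of the two numbers reported; only compound 2 stands beside it as a number. Compound 2, `Cc1cc(Nc2cc(-c3ccccc3)[nH]n2)n2nc(SCc3ccc(F)cc3)nc2n1`, gives 8110 nM in this assay. Compound 3, `CCCCCc1c(C)nc2nc(SCc3ccc(Cl)cc3)nn2c1Nc1cc(-c2ccccc2)[nH]n1`, carries a longer chain on the core and reaches only the limit > 50000 nM in this assay, a limit and not a number (the limit of > 50000 nM in this assay, at which 1 of the 3 values shown sits).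

The step now followed leads from compound 1 to compound 4, `Cc1cc(Nc2cc(-c3ccccc3)[nH]n2)n2nc(SCc3ccc(Cl)cc3)nc2n1`, which is not yet measured in this assay. The change is 4-chlorophenyl in place of benzyl on a saturated chain carbon bound to a sulfur. Within the data shown here, the one measured step that touches the same place, a 1.6-fold higher number from compound 1 to compound 2 (0.22 log units; within the scatter), stays inside the usual scatter, and the change to compound 4 is of the same kind, read one bond further out as phenethyl to 4-chlorobenzyl. Compound 3 carries the same (4-chlorobenzyl)sulfanyl group, but its second difference on the core keeps it from bearing directly on this step. The author therefore expects no step beyond the scatter in this assay, if anything a slightly higher number, and estimates a 1.8-fold higher number from compound 1 to compound 4 (0.26 log units; within the scatter) for compound 4. Compound 4 is expected to give about 9000 nM in this assay, in the range 3000 nM to 30000 nM.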

Compound 4, half-maximal inhibitory concentration: 6710 nM
Compound 4: the middle estimate sits 1.3-fold (0.13 log units) above what was measured, within the range that was stated.
By their numbers in this assay, from the lowest: compounds 1, 4 and 2 (each within the scatter of the next). At a limit, above all of these: compound 3.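

In this assay, the new compound shows that chloro and fluoro on the aromatic ring of the thioether group cannot be told apart, with a 1.2-fold lower number from compound 2 to compound 4 (0.08 log units; within the scatter), and the change from phenethyl to 4-chlorobenzyl on the sulfur also stays small, with a 1.4-fold higher number from compound 1 to compound 4 (0.13 log units; within the scatter). Compound 4 also gives the first comparison with compound 3 that differs in one place, and hydrogen in place of pentyl on an aromatic carbon of the shared core gives an at least 7.4-fold lower number from compound 3 to compound 4 (0.87 log units; beyond the scatter), the only step shown that lies beyond the scatter, so the largest difference seen here lies on the core and not on the thioether group. The entry for compound 3 is a limit of the assay and not a number: the limit of > 50000 nM in this assay, at which 1 of the 4 values shown sits.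

How a chain shorter than pentyl, such as ethyl, would read on that aromatic carbon remains open, so the compounds shown do not tell where between hydrogen and pentyl the number begins to rise. Also open, on these data alone, is whether an amine or a carboxylic acid on the aromatic ring of the thioether group would produce a step beyond the scatter.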